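Replacing Methyl with (2-Nitrophenyl)sulfonyl in Compound 3

The compounds below may be only part of what the source reports. "The series", "measured", "known", "first", "only" and "open" are said of these compounds alone.

In a functional assay on KB cells (Homo sapiens) for cytotoxicity, read by MTT assay, with a stated time of 3 days (on this read-out lower numbers stand for stronger inhibition and higher numbers for weaker inhibition), compound 1 (`N#Cc1c(Cl)nc(SCc2nc3ccccc3[nH]2)nc1-c1ccccc1`) gives 3.7 nM and compound 2 (`CN1CCN(c2nc(SCc3nc4ccccc4[nH]3)nc(-c3ccccc3)c2C#N)CC1`) gives 2.7 nM so the two stand within the scatter of each other. Compound 3 (`N#Cc1c(-c2ccccc2)nc(SCc2nc3ccccc3[nH]2)nc1N1CCN(S(=O)(=O)c2ccccc2[N+](=O)[O-])CC1`) differs from compound 2 by (2-nitrophenyl)sulfonyl in place of methyl on an amine nitrogen in a ring. Going by the values given here, the one measured step (a 1.4-fold lower number from compound 1 to compound 2 (0.14 log units; within the scatter)) put 4-methylpiperazin-1-yl in place of chloro on an aromatic carbon and lay within the scatter, but it offers no direct guide to this change. A modest estimated step (a 1.9-fold higher number from compound 2 to compound 3 (0.27 log units; within the scatter)) towards a higher number is expected. Compound 3 is expected at about 5 nM (estimated range 1 nM to 30 nM) once measured.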

Compound 3, half-maximal inhibitory concentration: 4.44 nM
Estimate against measurement, compound 3: 1.1-fold (0.05 log units) above; low and high end bracket the measured number.
By their numbers in this assay, from the lowest: compounds 2, 1 and 3 (each within the scatter of the next).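

At the amine nitrogen in the ring, this assay records a 1.6-fold higher number from compound 2 to compound 3 (0.22 log units; within the scatter) when (2-nitrophenyl)sulfonyl takes the place of methyl. The earlier step concerned only an aromatic carbon; this one shows that this nitrogen can carry a much larger group, with its own six-membered aromatic ring, without the number leaving the scatter. Nothing measured here speaks to the reason for this outcome. As far as these compounds go, whether an acetyl group, a plain phenylsulfonyl group or a carboxylic acid on a longer chain would be tolerated on this nitrogen remains open.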